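This account rests on a few compounds, and the source may have more. Where it says the series, first, only, none or still open, it means among the compounds named here.

Measured compounds:
Compound 1 `Fc1ccc(Oc2ccc3c(NCCCNCc4ccco4)ccnc3c2)cc1`, which in an ADME assay for permeability, using PAMPA, with a stated time of 30 min, at pH 7.4 (a lower number here means that the compound crosses the layer more slowly, a higher number that the compound crosses the layer faster), gives 317 10^-6 cm/s.
Compound 2 `COc1ccccc1Oc1ccc2c(NCCCNCc3ccco3)ccnc2c1`, which in this assay gives 317 10^-6 cm/s.
Compound 3 `N#Cc1ccc(Cc2ccc3c(NCCCNCc4ccco4)ccnc3c2)cc1`, which in this assay gives 23 10^-6 cm/s.

Compound 3 gives the lowest of these three numbers: a 14-fold lower number from compound 1 to compound 3 (1.14 log units; beyond the scatter) and a 14-fold lower number from compound 2 to compound 3 (1.14 log units; beyond the scatter). Compound 4 `c1coc(CNCCCNc2ccnc3cc(-c4cccc5ccccc45)ccc23)c1` differs from compound 3 in one place: naphthalen-1-yl in place of 4-cyanobenzyl on an aromatic carbon. Going by the values given here, no measured step makes exactly this change. The two steps that introduced the 4-cyanobenzyl group bear on it, and both were large; compound 4 instead carries a group with no hydrogen-bond acceptors, as compound 1 and compound 2 do. A sizable upward step in this assay is therefore expected, an 8.7-fold higher number from compound 3 to compound 4 (0.94 log units; beyond the scatter), with a wide range since the naphthalen-1-yl group is not an aryl ether. Compound 4 is estimated at 200 10^-6 cm/s, between 70 10^-6 cm/s and 400 10^-6 cm/s.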

Compound 4, apparent permeability: 237 10^-6 cm/s
The estimate for compound 4 lay 1.2-fold (0.07 log units) below the measured number; the measured number falls inside the stated range.
By their numbers in this assay, from the lowest: compound 3; then compounds 4, 1 and 2 (each within the scatter of the next).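

Going by these compounds alone, at this aromatic carbon, the 4-cyanobenzyl group of compound 3 is the only one of the four groups that gives a low number in this assay: replacing it with naphthalen-1-yl gives a 10-fold higher number from compound 3 to compound 4 (1.01 log units; beyond the scatter). An oxygen link is not required for the higher level, since a 1.3-fold lower number from compound 2 to compound 4 (0.13 log units; within the scatter) and a 1.3-fold lower number from compound 1 to compound 4 (0.13 log units; within the scatter). No measurement shown here explains the large step. Still open, from the compounds shown here alone, is whether the nitrile or the benzyl linkage accounts for the low number of compound 3; plain benzyl and 4-cyanophenyl at this carbon would separate the two.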